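Methylsulfonylpiperazine Replaces Sulfo at the Chain End

This account rests on a few compounds, and the source may have more. Where it says the series, first, only, none or still open, it means among the compounds named here.

Compound 1 `COc1cc(N)c(Cl)cc1C(=O)NC1CCN(CCCCCCCCO)CC1` — in a functional assay on HEK293 cells for activation of 5-hydroxytryptamine receptor 4 (Homo sapiens), read by cAMP accumulation (a lower number here means a smaller maximal response, a higher number a larger maximal response), compound 1 gives > 100%, a limit of the assay rather than a number.
Compound 2 `COc1cc(N)c(Cl)cc1C(=O)NC1CCN(CCCCCCCCS(=O)(=O)O)CC1` — compound 2 gives > 100%, likewise only a limit.
Compound 3 `COc1cc(N)c(Cl)cc1C(=O)NC1CCN(CCCCCN2CCN(S(C)(=O)=O)CC2)CC1` — compound 3 gives > 100%, again a limit.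

The three measured compounds share one core and differ only in the group carried at the end of the chain on the ring amine nitrogen. Compound 2 therefore stands where the other two stand, because all three sit at the limit of > 100% in this assay, at which 3 of the 3 values shown sit. For that reason the steps a step that the two limits leave unreadable from compound 1 to compound 2, a step that the two limits leave unreadable from compound 1 to compound 3 and a step that the two limits leave unreadable from compound 2 to compound 3 cannot be given a size or a direction.

Compound 4 `COc1cc(N)c(Cl)cc1C(=O)NC1CCN(CCCCCCCCN2CCN(S(C)(=O)=O)CC2)CC1` has not yet been measured. It differs from compound 2 by 4-(methylsulfonyl)piperazin-1-yl in place of sulfo on a saturated chain carbon, eight bonds along the chain from an amine nitrogen in a ring. Going by the values given here, the steps that bear on this change are exactly the three unreadable ones, so no size of step beyond the scatter can be predicted; the only signal is that every measured compound reaches the limit. The step expected on this basis is a step that the limit leaves unreadable from compound 2 to compound 4. For compound 4 the estimated value is 105%, with a range from 90% to 125%, most likely reported again as a limit.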

Compound 4, intrinsic activity: the largest response reached, in percent of the reference agonist's: > 100%
Compound 4: no number, only a limit (the forecaster's own chance of this, stated with the estimate: 80%); the middle value is on the limit's open side.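

No new step can be read: the steps from compound 1 and compound 2 to compound 4 in this assay have neither size nor direction, because all the values stand at one limit: the limit of > 100% in this assay, at which 4 of the 4 values shown sit.

The compounds shown leave open how large each maximal response is and whether the group at the chain end changes it.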